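The compounds below may be only part of what the source reports. "The series", "measured", "known", "first", "only" and "open" are said of these compounds alone.

Measured compounds:
compound 1 `COc1ccc(/C=C/c2cc(OC)cc(OC)c2/C=C/C(=O)c2cc3cc(OC)ccc3oc2=O)cc1`: > 60000 nM
compound 2 `COc1ccc(/C=C/c2cc(OC)cc(OC)c2/C=C/C(=O)c2cc3cccc(C)c3oc2=O)cc1`: > 60000 nM

In an assay on isolated protein for inhibition of Amine oxidase [flavin-containing] A (Homo sapiens), read by fluorescence, with a stated time of 15 min (on this read-out lower numbers stand for stronger inhibition and higher numbers for weaker inhibition), compound 1 gives only a limit, > 60000 nM, not a number. Compound 2 likewise reaches only a limit in this assay, > 60000 nM. Both values sit at the limit of > 60000 nM in this assay, at which 2 of the 2 values shown sit, so compound 1 cannot be placed against compound 2 on the numbers shown, and no step between measured compounds is available.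

Compound 3 `COc1ccc(/C=C/c2cc(OC)cc(OC)c2/C=C/C(=O)c2cc3cc(Cl)ccc3oc2=O)cc1` is not yet measured in this assay. It differs from compound 1 by chloro in place of methoxy on an aromatic carbon. For the measured compounds named here, with no measured step and both known values at the limit, no change beyond the scatter is expected on going from compound 1 to compound 3, and the most likely outcome is again a limit rather than a number. The expected step is a step that the limit leaves unreadable from compound 1 to compound 3. Compound 3 is accordingly expected at 70000 nM, with a range from 20000 nM to 200000 nM.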

Compound 3, half-maximal inhibitory concentration: > 60000 nM
Compound 3: only a limit was reported (the forecaster's own chance of this, stated with the estimate: 75%); the middle value is on the limit's open side.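

For the compounds shown here, compound 3 gives only a limit in this assay and so no step from compound 1 or compound 2 to compound 3 can be read: the limit of > 60000 nM in this assay, at which 3 of the 3 values shown sit.
The compounds shown leave open how far any of the three lies from that limit, and whether chloro in place of methoxy changes inhibition at all.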